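The source may report more compounds than this note shows. Statements on the series, on what has been measured and on what is new or still open speak of the compounds shown alone.

Measured so far:
compound 1, `Cc1cccc(Oc2ccnc(N3CCC[C@H]3C(=O)NCCCn3ccnc3)n2)c1` — 2%
compound 2, `CN(CCCn1ccnc1)C(=O)[C@@H]1CCCN1c1nccc(Nc2ccccc2)n1` — 3%

In an assay on isolated protein for inhibition of tyrosine-protein kinase ZAP-70 (Homo sapiens), read by HTRF, tested at 10 uM (on this read-out higher numbers stand for more inhibition at the one concentration tested (going by the name of the read-out) and lower numbers for less inhibition), compound 1 gives 2%. Compound 2 gives 3% in this assay. Compound 1 thus stands at the lower of the two numbers, but the gap to compound 2 lies within the scatter, so the two compounds cannot be told apart on this read-out, and both sit near the floor of the scale.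

Compound 3, `COC(=O)C(CO)NC(=O)[C@@H]1CCCN1c1nccc(Oc2cccc(C)c2)n1`, is the next compound to be tested in this assay. Relative to compound 1 the change is 2-hydroxy-1-(methoxycarbonyl)ethyl in place of 3-(1H-imidazol-1-yl)propyl on an amide-type nitrogen. Within the data shown here, no step between two measured compounds is available to calibrate this change. Since compound 1 and compound 2 both sit near the floor, the step is expected to be none beyond the scatter: a number 1 percentage points higher from compound 1 to compound 3 (within the scatter). Compound 3 is therefore estimated at 3%, with a range from -6% to 12%.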

Compound 3, a percentage reported as inhibition, at one concentration (the size of the read-out at that concentration, not a potency): 0%
Compound 3: middle estimate off by 3 percentage points, on the high side; the measured number falls inside the stated range.
By their numbers in this assay, from the lowest: compounds 3, 1 and 2 (each within the scatter of the next).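

In this assay, putting 2-hydroxy-1-(methoxycarbonyl)ethyl in place of 3-(1H-imidazol-1-yl)propyl on the amide-type nitrogen gives a number 2 percentage points lower from compound 1 to compound 3 (within the scatter), the first step read at this position. Even with the five-membered aromatic ring gone and an open chain with a methoxycarbonyl group and a hydroxyl in its place, compound 3 gives 0%, so this exchange leaves the number very small, where a loss could not show. Nothing available explains this result or bears on it.

Going by these compounds, whether any group on this nitrogen can lift the number off the floor stays open, for instance a primary amine, a carboxylic acid or a longer alkyl chain. With the shared core at the floor in all three compounds, the compounds shown cannot say whether this position matters for inhibition at all.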